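The source may hold more compounds than are shown below. What is called first, only, known or untested is meant among the compounds shown, and "the series" means these compounds.

Compound 1 `CN1CCN(C(=O)c2cc3c(Nc4ccc(OC(F)(F)F)cc4)ncnc3s2)CC1`: 2690 nM
Compound 2 `CNC(=O)c1cccc(-c2cc(Nc3ccc(OC(F)(F)F)cc3)ncn2)c1`: > 10000 nM
Compound 3 `NC(=O)c1cccc(Oc2cc(Nc3ccc(OC(F)(F)F)cc3)ncn2)c1`: > 10000 nM

Going by the values given here, in an ADME assay on BaF3 cells (Mus musculus) for cytotoxicity (a higher number here means that more compound is needed for the effect, a lower number that less compound is needed), compound 1 gives 2690 nM, the only actual number in this small set. Compound 2 reads > 10000 nM, which is a limit of the assay. Compound 3 reads > 10000 nM, which is also a limit. The rest of the picture is thus (the limit of > 10000 nM in this assay, at which 2 of the 3 values shown sit).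

Compound 4 `COC(=O)c1cc2c(Nc3ccc(OC(F)(F)F)cc3)ncnc2s1` has not yet been measured. It keeps the core of compound 1 and carries methoxy in place of 4-methylpiperazin-1-yl on a carbonyl carbon. Among the compounds with values here, no measured step covers this change, so the expectation is a loose one. Within the data shown here, a moderate step upward in this assay, beyond the scatter, is expected, since compound 1 at 2690 nM is the only compound that gave a number at all. A reading at the limit would not be a surprise.

The expected move is a 2.2-fold higher number from compound 1 to compound 4 (0.35 log units; beyond the scatter). For compound 4 the estimate is 6000 nM, with an expected range of 2000 nM to 10000 nM.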

Compound 4, half-maximal effective concentration: > 10000 nM
Compound 4 ended at the assay's limit; the forecaster's own chance of this, stated with the estimate: 30%; middle value at least 1.6-fold (0.22 log units) from the limit.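

In this assay, going by these compounds alone, methoxy in place of 4-methylpiperazin-1-yl on a carbonyl carbon gives an at least 3.7-fold higher number from compound 1 to compound 4 (0.57 log units; beyond the scatter), the first step in this set that can be read between two compounds differing in one place. Compound 4 reads > 10000 nM, which is a limit of the assay. The change shows that, on the shared core, the group on this carbonyl carbon affects the reading, and that compound 1 remains the only compound with an actual number: the limit of > 10000 nM in this assay, at which 3 of the 4 values shown sit.

The compounds shown leave open whether the step belongs to the whole 4-methylpiperazin-1-yl group or to only part of it, which a piperazine without the methyl or a morpholine on the same carbonyl carbon would help separate. They also leave open how a carboxylic acid or a simple amine amide at this place would read.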